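A few compounds are considered here, and "the series" means these few. Any claim that something is new, unique, unknown or untested is made for them only; others in the source may bear on it.

Measured in an ADME assay on microsomes from liver (Homo sapiens) for metabolic stability; on this read-out higher numbers stand for a longer-lived compound and lower numbers for a shorter-lived compound:
compound 1 `CC(C)C(Cc1ncc[nH]1)c1ccc(-c2ccc3cccc(F)c3c2)[nH]c1=O` gives 0.106 h
compound 2 `CC(C)C(Cc1nnn[nH]1)c1ccc(-c2ccc3cccc(F)c3c2)[nH]c1=O` gives > 3 h

For compound 2 the figure is only a limit of the assay, not a number (the limit of > 3 h in this assay, at which 1 of the 2 values shown sits). Compound 3 `Cc1c[nH]c(C(c2ccc(-c3ccc4cccc(F)c4c3)[nH]c2=O)C(C)C)n1` differs from compound 2 in one place: 4-methyl-1H-imidazol-2-yl in place of (1H-tetrazol-5-yl)methyl on a saturated chain carbon bound to an aromatic carbon and a saturated chain carbon. Among the measured compounds shown here, the one step measured so far bears on this change in reverse: an at least 28-fold higher number from compound 1 to compound 2 (1.45 log units; beyond the scatter). Going back from the tetrazole to an imidazole is therefore expected to undo most of that gain, a large fall estimated as an at least 20-fold lower number from compound 2 to compound 3 (1.30 log units; beyond the scatter). Compound 3 is thus expected at about 0.15 h, within a range of 0.05 h to 0.6 h.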

Compound 3, half-life: 0.09 h
For compound 3 the middle estimate is 1.7-fold (0.22 log units) above the measured one; measured number inside the range.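

In this assay, replacing the (1H-tetrazol-5-yl)methyl group with 4-methyl-1H-imidazol-2-yl gives an at least 33-fold lower number from compound 2 to compound 3 (1.52 log units; beyond the scatter). The figure for compound 2 is a limit of the assay, not a number: the limit of > 3 h in this assay, at which 1 of the 3 values shown sits. The two imidazole compounds stay level, with a 1.2-fold lower number from compound 1 to compound 3 (0.07 log units; within the scatter), so a second, differently attached imidazole does not recover the high number seen with the tetrazole.

Going by these compounds, whether a carboxylic acid or an amine on this chain would match the tetrazole remains open. So does the true half-life of compound 2.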